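The source may hold more compounds than are shown below. What is called first, only, known or untested is meant among the compounds shown, and "the series" means these compounds.

Compound 1 `CCOC(=O)c1sc(-c2cccc(NC(=O)c3ccccc3)c2)nc1Nc1ccc(N2CCN(C)CC2)cc1` is a compound whose amide carries a plain benzene ring; in a functional assay on Raji cells (Homo sapiens) for antiproliferative activity, read by CCK-8 assay, with a stated time of 72 h, tested at 40 uM (a lower number here means less inhibition, a higher number more inhibition at the concentration tested (going by the name of the read-out)), compound 1 gives 42%. Compound 2 `CCOC(=O)c1sc(-c2cccc(NC(=O)c3ccc(C#N)cc3)c2)nc1Nc1ccc(N2CCN(C)CC2)cc1` differs only in a cyano group on that ring, and in this assay compound 2 gives 79.1%. For the measured compounds named here, the single measured step, a number 37.1 percentage points higher from compound 1 to compound 2 (beyond the scatter), is therefore a large gain. Going by the values given here, compound 2 stands highest of the two numbers so far, with compound 1 as its only neighbour, lower by that same margin.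

Compound 3 `CCOC(=O)c1sc(-c2cccc(NC(=O)c3ccco3)c2)nc1Nc1ccc(N2CCN(C)CC2)cc1` replaces the aromatic group on the amide carbonyl: furan-2-yl in place of 4-cyanophenyl on a carbonyl carbon. Among the compounds with values here, no measured step matches this swap exactly. Within the data shown here, the one step available shows that removing the cyano group alone costs a great deal, and compound 3 has neither the cyano group nor the benzene ring it sat on. Among the measured compounds shown here, the expectation is a fall in this assay, with a number 34.1 percentage points lower from compound 2 to compound 3 (beyond the scatter), because compound 1 gives 42% without a cyano group and a furan ring has no measured precedent here. Compound 3 is therefore estimated at 45%, likely between 25% and 68%.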

Compound 3, a percentage reported as inhibition, at one concentration (the size of the read-out at that concentration, not a potency): 87.6%
For compound 3 the middle estimate is 42.6 percentage points below the measured one; measured number above the stated range.
By their numbers in this assay, from the lowest: compound 1; then compounds 2 and 3 (each within the scatter of the next).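

The new result changes the picture of the group on this carbonyl carbon: a high reading in this assay does not depend on the cyano group, or on a six-membered ring at all. Going from 4-cyanophenyl to furan-2-yl gives a number 8.5 percentage points higher from compound 2 to compound 3 (within the scatter) and so leaves the two compounds indistinguishable here, even though furan-2-yl is a smaller five-membered ring with one hetero atom and no nitrile. Going from phenyl to furan-2-yl gives a number 45.6 percentage points higher from compound 1 to compound 3 (beyond the scatter) and shows that, among these three amides, it is the plain phenyl compound that stands apart with the lowest reading, while nothing shown explains why these groups behave as they do.

From the compounds shown here alone, what remains open is whether the high reading needs an aromatic ring on this carbonyl carbon at all, or whether an open chain such as n-butyl or a saturated ring such as cyclohexyl would serve as well. Also open, going by these compounds, is how thiophen-2-yl or pyridin-3-yl would compare, and whether compound 2 and compound 3 would separate in a full concentration series, since each reading comes from a single concentration and is not a potency.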